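The source may report more compounds than this note shows. Statements on the series, on what has been measured and on what is new or still open speak of the compounds shown alone.

Measured in a physicochemical assay for solubility, using the shake flask method, measured as kinetic solubility, with a stated time of 20 h, at pH 2; a lower number here means a less soluble compound, a higher number a more soluble compound:

- Compound 1 `COc1cccnc1Nc1cc2[nH]c(-c3cccc(C(F)(F)F)c3)nc2cn1`: 116000 nM
- Compound 2 `COc1ccnc(Nc2cc3[nH]c(-c4cccc(C(F)(F)F)c4)nc3cn2)c1`: < 5000 nM (a limit of the assay, not a number)
- Compound 3 `FC(F)(F)c1cccc(-c2nc3cnc(Nc4ccncn4)cc3[nH]2)c1`: 200000 nM

Compound 3 stands at 200000 nM in this assay. It shares the top of the measured range with compound 1, as the step between them shows: a 1.7-fold higher number from compound 1 to compound 3 (0.24 log units; within the scatter).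

The next compound, compound 4 `FC(F)(F)c1cccc(-c2nc3cnc(Nc4cnccn4)cc3[nH]2)c1`, has pyrazin-2-yl in place of pyrimidin-4-yl on a nitrogen on an aromatic ring.

All three measured steps change the group at this same place. Two of them are large, and both involve compound 2: an at least 23-fold lower number from compound 1 to compound 2 (1.36 log units; beyond the scatter) and an at least 40-fold higher number from compound 2 to compound 3 (1.60 log units; beyond the scatter). The third is the small step already given, between the two compounds with real numbers. Neither group in the new swap carries the methoxy of compound 2, so the small step is the closer guide, although the large ones show that this place can matter and call for a wide range.

No change beyond the scatter is therefore expected, and the expected step is a 1.7-fold lower number from compound 3 to compound 4 (0.22 log units; within the scatter). Compound 4 is estimated at 120000 nM, with an expected range from 25000 nM to 300000 nM.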

Compound 4, solubility: 155000 nM
Compound 4: middle estimate off by 1.3-fold (0.11 log units), on the low side, within the range that was stated.
By their numbers in this assay, from the lowest: compounds 1, 4 and 3 (each within the scatter of the next). At a limit, below all of these: compound 2.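

The change from pyrimidin-4-yl to pyrazin-2-yl, which keeps the same atoms joined differently, makes no difference beyond the scatter in this assay: a 1.3-fold lower number from compound 3 to compound 4 (0.11 log units; within the scatter). Compound 4 also sits level with the methoxy-bearing compound 1, a 1.3-fold higher number from compound 1 to compound 4 (0.13 log units; within the scatter), so this position now holds three different groups that give numbers within the scatter of one another, and carrying a methoxy group does not by itself separate them. The large gap stays with compound 2 alone, an at least 31-fold higher number from compound 2 to compound 4 (1.49 log units; beyond the scatter), and its value is a limit of the assay, not a number: the limit of < 5000 nM in this assay, at which 1 of the 4 values shown sits.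

The compounds shown leave open how far the high numbers extend to other groups on this nitrogen, such as a pyridine ring bearing an amine or a carboxylic acid, and what separates 4-methoxypyridin-2-yl from 3-methoxypyridin-2-yl. On these data alone, all four compounds also keep the trifluoromethyl group, so it remains open whether the same picture would hold with a nitrile in its place.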